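This account rests on a few compounds, and the source may have more. Where it says the series, first, only, none or still open, it means among the compounds named here.

Measured compounds:
- compound 1, `Cc1ccc(C(/C=C/c2ccc(F)cc2)=N\Nc2nncc3ccccc23)cc1`: 5.6 nM
- compound 2, `Cc1cc(NS(=O)(=O)c2ccc(Nc3nncc4ccccc34)cc2)no1`: 46 nM

In a functional assay on MCF7 cells (Homo sapiens) for antiproliferative activity, read by sulforhodamine B assay, with a stated time of 72 h (on this read-out higher numbers stand for weaker inhibition and lower numbers for stronger inhibition), compound 1 gives 5.6 nM and compound 2 gives 46 nM; compound 2 carries the highest of the two numbers, and its nearest neighbour, compound 1, lies beyond the scatter with the lower number. The two differ in more than one place, so only the two values themselves can be set side by side.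

The next compound, compound 3, `O=S(=O)(Nc1ncccn1)c1ccc(Nc2nncc3ccccc23)cc1`, keeps the arrangement of compound 2 and changes one group: pyrimidin-2-yl in place of 5-methyl-1,2-oxazol-3-yl on a sulfonamide nitrogen. For the measured compounds named here, no pair of measured compounds shows this exchange, so there is no measured step to lean on.

Going by the values given here, with no comparable step available, the step from compound 2 to compound 3 is expected to stay within the scatter, in either direction, and is estimated as a 1.2-fold lower number from compound 2 to compound 3 (0.06 log units; within the scatter). Compound 3 is therefore expected to give about 40 nM in this assay, within a range of 12 nM to 130 nM.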

Compound 3, half-maximal inhibitory concentration: 64 nM
Beside the measured number, compound 3's estimate is 1.6-fold (0.20 log units) below it; the measured number falls inside the stated range.
By their numbers in this assay, from the lowest: compound 1; then compounds 2 and 3 (each within the scatter of the next).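

In this assay the first exchange read on the sulfonamide nitrogen gives a 1.4-fold higher number from compound 2 to compound 3 (0.14 log units; within the scatter) and so does not separate pyrimidin-2-yl from 5-methyl-1,2-oxazol-3-yl at this place. This single pair shows that a six-membered aromatic ring with 2 hetero atoms can stand in for a five-membered one with 2 hetero atoms, at the same count of heavy atoms and hydrogen-bond acceptors, with no reading beyond the scatter. Nothing at hand bears on why the two groups read alike.

From the compounds shown here alone, both groups on this nitrogen are aromatic rings, so how an open chain such as ethyl, or a plain hydrogen, would read there remains open. Compound 1 differs from both sulfonamides in more than one place, and what separates it from them stays unresolved.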